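This account rests on a few compounds, and the source may have more. Where it says the series, first, only, none or still open, it means among the compounds named here.

Of the compounds shown here, two have been measured in an assay on isolated protein for binding affinity to Alpha-1A adrenergic receptor (Rattus norvegicus), read by radioligand binding; a lower number here means a stronger inhibitor, a higher number a weaker inhibitor. Compound 1, `CCS(=O)(=O)Nc1cc(F)cc2c1CCCC2c1c[nH]cn1`, gives 83.2 nM in this assay. Compound 2, `CS(=O)(=O)Nc1ccc(O)c2c1CCCC2c1c[nH]cn1`, gives 708 nM in this assay, the higher of the two numbers; the gap to compound 1 is beyond the usual scatter, so compound 2 is the weaker binder of the pair on these data. Going by the values given here, no single-point step between the two measured compounds is available, because they differ in more than one place.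

Compound 3, `COc1ccc(NS(C)(=O)=O)c2c1C(c1c[nH]cn1)CCC2`, differs from compound 2 in one place: methyl in place of hydrogen on an oxygen on an aromatic ring. No measured pair shows what this change does in this assay, so the direction rests on judgement rather than on a shown step. The change is small in size, and the expectation is a step of a 1.4-fold higher number from compound 2 to compound 3 (0.15 log units; within the scatter), that is, a modest move, likely towards a somewhat higher number but possibly within the scatter. Compound 3 is therefore expected to give about 1000 nM in this assay, with a plausible range from 350 nM to 2800 nM.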

Compound 3, inhibition constant: 1700 nM
The estimate for compound 3 lay 1.7-fold (0.23 log units) below the measured number; low and high end bracket the measured number.
By their numbers in this assay, from the lowest: compound 1; then compound 2; then compound 3.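

Replacing the hydroxy group with a methoxy group weakens binding in this assay, giving a 2.4-fold higher number from compound 2 to compound 3 (0.38 log units; beyond the scatter). Going by these compounds alone, this is the first comparison in the set in which only one place changes, and it shows that the number responds even to one added carbon on this oxygen, although the step is only modest in size. No measurement here bears on why the number rises, so the result records an effect without an explanation.

The compounds shown leave open whether a longer chain on this oxygen, such as ethoxy, would raise the number further, and whether an amine in place of the hydroxy group would keep binding at the level of compound 2 or move it in either direction. Compound 1, the strongest binder of the three at 83.2 nM, differs from compound 2 and compound 3 in more than one place, so the compounds shown do not reveal which of its differences accounts for its lower number.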